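Moving the nitrile: 4-cyanophenyl to 2-cyanophenyl

The compounds below may be only part of what the source reports. "The series", "measured", "known", "first", "only" and "open" are said of these compounds alone.

For the measured compounds named here, in a functional assay on B16 cells (Mus musculus) for antiproliferative activity, read by MTT assay, with a stated time of 24 h (a lower number here means a stronger inhibitor, a higher number a weaker inhibitor), compound 1 `COc1cc(OC)c(-c2coc3cc(OCc4ccccc4C)ccc3c2=O)cc1OC` gives 2150 nM and compound 2 `COc1cc(OC)c(-c2coc3cc(OCc4ccc(C#N)cc4)ccc3c2=O)cc1OC` gives 7000 nM, the higher of the two numbers so far. Compound 3 `COc1cc(OC)c(-c2coc3cc(OCc4ccccc4C#N)ccc3c2=O)cc1OC` carries 2-cyanophenyl in place of 4-cyanophenyl on a saturated chain carbon bound to an oxygen on an aromatic ring. Going by the values given here, only one measured step bears on this change: a 3.3-fold higher number from compound 1 to compound 2 (0.51 log units; beyond the scatter), a modest step beyond the scatter. It swaps the group and its numbering together, so the data do not separate the two. Compound 3 shares the nitrile with compound 2 at 7000 nM, and its 2-cyanophenyl matches the 2-methylphenyl of compound 1 at 2150 nM, so a number near or between these two is expected. The expected change is a modest one toward a lower number: a 1.8-fold lower number from compound 2 to compound 3 (0.24 log units; within the scatter). For compound 3 the estimate is 4000 nM, with an expected range of 1600 nM to 10000 nM.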

Compound 3, half-maximal inhibitory concentration: 2140 nM
Beside the measured number, compound 3's estimate is 1.9-fold (0.27 log units) above it; the range from low to high includes it.
By their numbers in this assay, from the lowest: compounds 3 and 1 (each within the scatter of the next); then compound 2.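

In this assay, moving the nitrile gives a 3.3-fold lower number from compound 2 to compound 3 (0.51 log units; beyond the scatter), so the place of the group on the phenyl ring counts here, which the earlier step could not separate from the change of group. With the numbering held, cyano in place of methyl on an aromatic carbon gives a 1.0-fold lower number from compound 1 to compound 3 (0.00 log units; within the scatter), so nitrile and methyl are not told apart, and across these three compounds the number follows the numbering rather than the group. Nothing at hand explains this difference between 4-cyanophenyl and 2-cyanophenyl.

Open, from the compounds shown here alone, is whether an amine or a carboxylic acid in place of the nitrile of compound 3 would fit the same reading. Also open, going by these compounds, is whether a longer chain in place of the saturated chain carbon bound to the oxygen would preserve the gap seen with 2-cyanophenyl and 4-cyanophenyl.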